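Halogen swap on the pendant aryl ring of compound 1

The source may hold more compounds than are shown below. What is called first, only, known or untested is meant among the compounds shown, and "the series" means these compounds.

Measured so far in a functional assay on Huh-7 cells (Homo sapiens) for inhibition, read by sulforhodamine B assay, with a stated time of 72 h; on this read-out lower numbers stand for stronger inhibition and higher numbers for weaker inhibition:
compound 1 `CC(c1ccc(-c2ccccc2)c(F)c1)c1nnc2n1N=C(c1ccc(Cl)cc1)CS2` — 3900 nM
compound 2 `COc1ccc2cc(C(C)c3nnc4n3N=C(c3ccc(C)cc3)CS4)ccc2c1` — 8200 nM
compound 3 `COc1ccc2cc(C(C)c3n[nH]c(=S)n3N)ccc2c1` — 40800 nM

Compound 1 stands with the lowest number of the three. The gap to compound 2 and the larger gap to compound 3 both lie beyond the scatter, so compound 1 is the most potent of the measured set. Compound 4 `CC(c1ccc(-c2ccccc2)c(F)c1)c1nnc2n1N=C(c1ccc(F)cc1)CS2` has not been measured; it differs from compound 1 in one place: fluoro in place of chloro on an aromatic carbon. Within the data shown here, no measured pair shows this change, so the expectation rests on compound 1 alone. A small step toward a weaker number is expected, close to the scatter; the step expected is a 1.4-fold higher number from compound 1 to compound 4 (0.15 log units; within the scatter) in this assay. Compound 4 is estimated at 5500 nM, with a range from 2500 nM to 12000 nM.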

Compound 4, half-maximal inhibitory concentration: 4900 nM
Compound 4: the middle estimate sits 1.1-fold (0.05 log units) above what was measured; low and high end bracket the measured number.
By their numbers in this assay, from the lowest: compounds 1, 4 and 2 (each within the scatter of the next, the first and the last beyond it); then compound 3.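

In this assay the change from 4-chlorophenyl to 4-fluorophenyl gives a 1.3-fold higher number from compound 1 to compound 4 (0.10 log units; within the scatter) and so leaves no readable difference between the two halogens at this position. Among these compounds, this is the first single-place comparison, and on the pendant aryl ring it shows that fluoro serves as well as chloro on the shared core. No supporting measurement bears on the reason for this result.

Still open, as far as these compounds go, is how this position responds to a larger halogen such as bromo, or to a non-halogen group such as an amine, a nitrile or a carboxylic acid. Also open, from the compounds shown here alone, is whether the same halogen exchange reads alike with the methoxynaphthyl-bearing side of the series.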